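Chloro in place of hydroxy on compound 3

A few compounds are considered here, and "the series" means these few. Any claim that something is new, unique, unknown or untested is made for them only; others in the source may bear on it.

In a functional assay on T47D cells (Homo sapiens) for inhibition, read by CCK-8 assay, with a stated time of 72 h, tested at 10 uM (a lower number here means less inhibition of growth, a higher number more inhibition of growth at the concentration tested), compound 1 `CN(C)C(=O)c1cc2cnc(Nc3ccc(NC(=O)C4(C(=O)Nc5ccc(F)cc5)CC4)cc3)nc2n1C1CCCC1` gives 105%, compound 2 `CN(C)C(=O)c1cc2cnc(Nc3ccc(NC(=O)C4(C(=O)Nc5ccc(Cl)cc5)CC4)cc3)nc2n1C1CCCC1` gives 95% and compound 3 `CN(C)C(=O)c1cc2cnc(Nc3ccc(NC(=O)C4(C(=O)Nc5cccc(O)c5)CC4)cc3)nc2n1C1CCCC1` gives 83.7%, the lowest of the three numbers. Compound 4 `CN(C)C(=O)c1cc2cnc(Nc3ccc(NC(=O)C4(C(=O)Nc5cccc(Cl)c5)CC4)cc3)nc2n1C1CCCC1` has chloro in place of hydroxy on an aromatic carbon, meta to a large group (chloro in place of hydroxy on an aromatic carbon). The nearest measured step is a number 11.3 percentage points lower from compound 2 to compound 3 (beyond the scatter), with 3-hydroxyphenyl replacing 4-chlorophenyl. Replacing 4-fluorophenyl gave a number 21.3 percentage points lower from compound 1 to compound 3 (beyond the scatter), while chloro for fluoro gave a number 10 percentage points lower from compound 1 to compound 2 (within the scatter). For the measured compounds named here, no measured compound carries 3-chlorophenyl, so the transfer is uncertain. A modest rise is expected, with an estimated step of a number 11.3 percentage points higher from compound 3 to compound 4 (beyond the scatter). For compound 4 the expected value is 95%, with an estimated range of 82% to 107%.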

Compound 4, percent growth inhibition at one concentration: 92.6%
Estimate against measurement, compound 4: 2.4 percentage points above, and the stated range covers the measured number.
By their numbers in this assay, from the lowest: compounds 3, 4, 2 and 1 (each within the scatter of the next, the first and the last beyond it).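

In this assay chloro in place of hydroxy on the 3-substituted phenyl is not resolved (a number 8.9 percentage points higher from compound 3 to compound 4 (within the scatter)). The position of chloro is also not resolved, with 3-chlorophenyl in place of 4-chlorophenyl (a number 2.4 percentage points lower from compound 2 to compound 4 (within the scatter)), while 3-chlorophenyl in place of 4-fluorophenyl gives a step beyond the scatter (a number 12.4 percentage points lower from compound 1 to compound 4 (beyond the scatter)). No evidence on the cause of these steps accompanies the numbers. Open, on these data alone, is how an amine, a carboxylic acid or a methoxy group would read on this carbon. Also open, as far as these compounds go, is whether 3-fluorophenyl would read with compound 1 or with compound 4.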